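Aryl extension on the methoxy carbon of compound 2

The compounds below may be only part of what the source reports. "The series", "measured", "known", "first", "only" and "open" are said of these compounds alone.

Two members of the series carry numbers in a functional assay on CHO cells for agonist activity at metabotropic glutamate receptor 2 (Homo sapiens), read by GTPgammaS binding; on this read-out lower numbers stand for an effect already at smaller amounts and higher numbers for an effect only at larger amounts of compound. Compound 1 `CCCn1ccc2cc(-c3ccc(N(C)C)nc3)cc(Cl)c2c1=O` gives 5010 nM in this assay. Compound 2 `CCCn1ccc2cc(-c3ccc(OC)cc3)cc(Cl)c2c1=O` gives 316 nM in this assay, the lowest of the two numbers shown; its nearest neighbour is compound 1, and the gap between them lies beyond the scatter of repeated runs. The next member, compound 3 `CCCn1ccc2cc(-c3ccc(OCc4ccc(Cl)nc4)cc3)cc(Cl)c2c1=O`, differs from compound 2 in a single place: 6-chloropyridin-3-yl in place of hydrogen on a saturated chain carbon bound to an oxygen on an aromatic ring. Among the measured compounds shown here, no step between two measured compounds covers a change of this kind, so the direction and size of the step rest on judgement rather than on a precedent from the series. The step expected in this assay, a 1.6-fold lower number from compound 2 to compound 3 (0.20 log units; within the scatter), is a moderate lowering of the number, close to the edge of the scatter. For compound 3 the estimate in this assay is 200 nM, with a range from 50 nM to 1300 nM.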

Compound 3, half-maximal effective concentration: 398 nM
Compound 3: the middle estimate sits 2.0-fold (0.30 log units) below what was measured; low and high end bracket the measured number.
By their numbers in this assay, from the lowest: compounds 2 and 3 (each within the scatter of the next); then compound 1.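

Working from this assay, the change reads as a 1.3-fold higher number from compound 2 to compound 3 (0.10 log units; within the scatter), so 6-chloropyridin-3-yl in place of hydrogen on a saturated chain carbon bound to an oxygen on an aromatic ring leaves the number within the scatter. Among the compounds shown here, this is the first reading at this position: the methoxy carbon carries an added aromatic ring with no change in the number beyond the scatter, which no earlier pair could show. No measurement shown gives a reason for this result.

The compounds shown do not separate the contribution of the ring from that of its chlorine, which a phenyl or an unsubstituted pyridin-3-yl on the same carbon would address. Also open, on these data alone, is how this carbon responds to a group of another kind, such as an amine, a carboxylic acid or a longer alkyl chain.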